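Swapping the dichlorophenyl for a hydroxymethylphenyl group

The source may hold more compounds than are shown below. What is called first, only, known or untested is meant among the compounds shown, and "the series" means these compounds.

Compounds measured so far:
Compound 1 `O=C1Nc2ccc(Br)cc2/C1=N/NC(=S)N/N=C/c1c(F)cccc1Cl`: 2560 nM
Compound 2 `O=C1Nc2ccc(Br)cc2/C1=N/NC(=S)N/N=C/c1c(Cl)cccc1Cl`: 6730 nM

In a functional assay on COS-7 cells (Chlorocebus aethiops) for inhibition, read by MTT assay (on this read-out lower numbers stand for stronger inhibition and higher numbers for weaker inhibition), compound 2 gives the highest of the two numbers, with compound 1 its nearest neighbour at a lower value. Among the compounds with values here, the only measured step, a 2.6-fold higher number from compound 1 to compound 2 (0.42 log units; beyond the scatter), is a modest one. Compound 3 `Cc1ccc(O)c(/C=N/NC(=S)N/N=C2\C(=O)Nc3ccc(Br)cc32)c1` differs from compound 2 by 2-hydroxy-5-methylphenyl in place of 2,6-dichlorophenyl on a carbon with a double bond to nitrogen. Within the data shown here, that is a larger change than the single step measured, which touched only one halogen on the same ring, so it gives only a loose guide: the weaker number of compound 2 arose from a halogen swap, and the new ring carries no halogen at all. Among the measured compounds shown here, with no closer precedent, compound 3 is expected to land between the two measured values or somewhat stronger, an estimated step of a 1.9-fold lower number from compound 2 to compound 3 (0.28 log units; within the scatter), giving an expected 3500 nM with a range of 1000 nM to 12000 nM.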

Compound 3, half-maximal inhibitory concentration: > 50000 nM
Compound 3 ended at the assay's limit; the forecaster's own chance of this, stated with the estimate: 5%; middle value at least 14-fold (1.15 log units) away from the limit.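

In this assay, this place on the carbon with a double bond to nitrogen tolerates far less than the halogen swap alone suggested: replacing the whole 2,6-dichlorophenyl group with 2-hydroxy-5-methylphenyl gives an at least 7.4-fold higher number from compound 2 to compound 3 (0.87 log units; beyond the scatter), and the comparison with the 2-chloro-6-fluorophenyl group gives an at least 19-fold higher number from compound 1 to compound 3 (1.29 log units; beyond the scatter). Compound 3 reads > 50000 nM, which is a limit of this assay and not a number. Among these three compounds, the two rings carrying halogens give readable numbers and the ring without halogens does not, and the full size of both steps stays unknown because the reading stops at the limit: the limit of > 50000 nM in this assay, at which 1 of the 3 values shown sits.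

This change removes the halogens and adds a hydroxyl and a methyl at once, so the compounds shown cannot say which part matters. As far as these compounds go, whether a ring bearing a methoxy group or an amine would restore a readable number also remains open.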